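A few compounds are considered here, and "the series" means these few. Any claim that something is new, unique, unknown or untested is made for them only; others in the source may bear on it.

Compound 1 `CCCCCCCCCCNc1ccn([C@H]2C[C@H](O)[C@@H](CO)O2)c(=O)n1`: 200000 nM
Compound 2 `CCCCCCCCCCNc1nc(=O)n([C@H]2C[C@H](O)[C@@H](CO)O2)cc1C`: 156000 nM

Both values come from an ADME assay on A549 cells (Homo sapiens) for cytotoxicity, read by MTT assay; on this read-out higher numbers stand for lower toxicity in this test and lower numbers for higher toxicity in this test. With only these two numbers, compound 2 stands level with compound 1, and a 1.3-fold lower number from compound 1 to compound 2 (0.11 log units; within the scatter) lies within the scatter. The next structure, compound 3 `CCCCCCCCCCNc1nc(=O)n([C@H]2C[C@H](OC(=O)OCCOCCOCCO)[C@@H](CO)O2)cc1C`, keeps everything in compound 2 except for one change: a group of 12 heavy atoms (7 carbon, 5 oxygen; no ring) in place of a hydrogen atom, on an oxygen on a saturated carbon. Among the measured compounds shown here, only one measured step exists, a methyl in place of hydrogen on an aromatic carbon. For the measured compounds named here, it is a different change at a different place, so it offers only weak guidance, and no measured compound carries a group on this oxygen. The data therefore point in no direction, and no step beyond the scatter is expected, though with real uncertainty. The expected step is a 1.2-fold lower number from compound 2 to compound 3 (0.08 log units; within the scatter). For compound 3 the estimated value is 130000 nM, with an expected range of 55000 nM to 280000 nM.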

Compound 3, half-maximal cytotoxic concentration: 90000 nM
Beside the measured number, compound 3's estimate is 1.4-fold (0.16 log units) above it; the measured number falls inside the stated range.
By their numbers in this assay, from the lowest: compounds 3, 2 and 1 (each within the scatter of the next, the first and the last beyond it).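

In this assay, placing a group of 12 heavy atoms on this oxygen gives a 1.7-fold lower number from compound 2 to compound 3 (0.24 log units; within the scatter) and so stays within the usual scatter of repeated measurements. Among the compounds shown here, this is the first reading for any group at this oxygen on a saturated carbon, and it shows that this particular open-chain group, with its one hydrogen-bond donor and five acceptors, can sit there without a clear shift in the read-out. Nothing measured here gives a reason for this result.

One group at one place cannot show whether this oxygen tolerates substitution in general. A simple acetyl group, a longer chain ending in an amine, or one ending in a carboxylic acid might behave alike or might move the number beyond the scatter.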